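Working notes on compound 1 and the unmeasured compound 3

A few compounds are considered here, and "the series" means these few. Any claim that something is new, unique, unknown or untested is made for them only; others in the source may bear on it.

compound 1 `COc1c(OCc2nc3ccccc3[nH]2)cc(O)c2c(=O)cc(-c3ccccc3)oc12`: > 100000 nM
compound 2 `CC(CO)NCCOc1c(O)cc(O)c2c(=O)cc(-c3ccccc3)oc12`: "not determined" (no result reported)
compound 3 `CCN(CC)CCCOc1cc(O)c2c(=O)cc(-c3ccccc3)oc2c1OC`: to be measured

In a functional assay on A549 cells (Homo sapiens) for cytotoxicity, read by MTT assay, with a stated time of 48 h (a lower number here means a stronger inhibitor, a higher number a weaker inhibitor), compound 1 gives > 100000 nM; this is a limit of the assay, not a number. Compound 1 thus stands at the limit of > 100000 nM in this assay, at which 1 of the 2 values shown sits, and the series has no single numeric value to anchor it, since compound 2 has no result reported in this assay. Going by the values given here, no pair of measured compounds differing in one place exists, so no measured step is available to set a scale for changes on the shared core.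

Compound 3 differs from compound 1 as follows: 2-(diethylamino)ethyl in place of 1H-benzimidazol-2-yl on a saturated chain carbon bound to an oxygen on an aromatic ring.

With the parent at a limit, no measured evidence fixes the direction or size of this change in this assay. Compound 3 is expected to give 40000 nM, with a range from 8000 nM to 200000 nM. Among the compounds with values here, the expected step of an at least 2.5-fold lower number from compound 1 to compound 3 (0.39 log units; beyond the scatter) rests on no measured pair and is given as an estimate only; a second limit for compound 3 remains a real possibility.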

Compound 3, half-maximal inhibitory concentration: 1830 nM
Beside the measured number, compound 3's estimate is 22-fold (1.34 log units) above it; the whole stated range lies above it.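

In this assay, replacing 1H-benzimidazol-2-yl with 2-(diethylamino)ethyl on a saturated chain carbon bound to an oxygen on an aromatic ring gives an at least 54-fold lower number from compound 1 to compound 3 (1.73 log units; beyond the scatter), which shows that this position can change the read-out strongly on the shared core. Compound 3, at 1830 nM, also gives the series its first single number, so the core of compound 1 can carry a substituent that brings the read-out within the measurable range of this assay. Compound 1 stands at a limit and not at a number, so the step gives only a minimum size: the limit of > 100000 nM in this assay, at which 1 of the 3 values shown sits.

Going by these compounds alone, the two structures do not separate the loss of the ring system from the arrival of the amine, since both happen in the one change from (1H-benzimidazol-2-yl)methyl to 3-(diethylamino)propyl. On these data alone, whether the read-out follows the amine itself remains open, and a 3-(dimethylamino)propyl group, a morpholine on the same chain, or a shorter or longer chain ending in diethylamino would each bear on that question.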